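This account rests on a few compounds, and the source may have more. Where it says the series, first, only, none or still open, it means among the compounds named here.

Measured so far:
compound 1 `COc1ccc(NS(=O)(=O)/C=C/c2c(F)c(F)c(F)c(F)c2F)cc1[N+](=O)[O-]`: in a functional assay on DU-145 cells (Homo sapiens) for cytotoxicity, read by trypan blue exclusion, with a stated time of 96 h (on this read-out lower numbers stand for stronger inhibition and higher numbers for weaker inhibition), compound 1 gives 100000 nM
compound 2 `COc1ccc(NS(=O)(=O)/C=C/c2c(F)c(F)c(F)c(F)c2F)cc1N`: compound 2 gives 75000 nM
compound 3 `COc1ccc(NS(=O)(=O)/C=C/c2cc(OC)c(OC)c(OC)c2)cc1[N+](=O)[O-]`: compound 3 gives 75000 nM

Compound 2 differs from compound 1 by amino in place of nitro on an aromatic carbon; that step was a 1.3-fold lower number from compound 1 to compound 2 (0.12 log units; within the scatter). Compound 3 has a different core; the difference between the two cores is not broken down here, and compound 3 and compound 2 give the same number at the digits printed. For the measured compounds named here, compound 4 `COc1ccc(NS(=O)(=O)/C=C/c2cc(OC)c(OC)c(OC)c2)cc1N` has not yet been measured and differs from compound 3 by amino in place of nitro on an aromatic carbon, the same change at the same place as the one from compound 1 to compound 2. Because the earlier change gave only a 1.3-fold lower number from compound 1 to compound 2 (0.12 log units; within the scatter), the expected step is small as well, about a 1.3-fold lower number from compound 3 to compound 4 (0.10 log units; within the scatter) in this assay. Compound 4 is therefore estimated at 60000 nM, likely between 30000 nM and 100000 nM.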

Compound 4, half-maximal inhibitory concentration: 35000 nM
The estimate for compound 4 lay 1.7-fold (0.23 log units) above the measured number; measured number inside the range.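

In this assay, amino in place of nitro gave a 2.1-fold lower number from compound 3 to compound 4 (0.33 log units; beyond the scatter), and set beside the earlier step, the change does not differ measurably between the two cores: the same change on two cores in this assay, a 1.3-fold lower number (0.12 log units; within the scatter) from compound 1 to compound 2 and a 2.1-fold lower number (0.33 log units; beyond the scatter) from compound 3 to compound 4, 1.6-fold (0.21 log units) apart, within the scatter of two such steps. For the compounds shown here, both steps run towards a lower number, although only the one on the core of compound 3 lies beyond the scatter. This rests on just two pairs, so it does not show that the change would behave alike on a third core, and it gives no reason for the size of either step.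

The compounds shown leave open what other groups on that aromatic carbon would give, such as a hydroxyl, an acetamide or a carboxylic acid. They also leave open whether the same change would carry over to other groups on the styryl ring, such as a single methoxy or a chlorine.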